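The source may report more compounds than this note shows. Statements on the series, on what has been measured and on what is new or still open speak of the compounds shown alone.

Compound 1 `CCNC(=O)N1CCN(C(=S)SCc2cn(Cc3ccccc3F)nn2)CC1` gives 23700 nM in a functional assay on EC9706 cells (Homo sapiens) for cytotoxicity, read by MTT assay, with a stated time of 72 h; on this read-out higher numbers stand for weaker inhibition and lower numbers for stronger inhibition.
Compound 2 `CC(C)NC(=O)N1CCN(C(=S)SCc2cn(Cc3ccccc3F)nn2)CC1` gives 20800 nM in this assay.
Compound 3 `CCNC(=O)N1CCN(C(=S)SCc2cn(Cc3ccc(Cl)cc3)nn2)CC1` reaches only the limit of > 128000 nM in this assay, so no number is known for it.

Compounds 1 and 2 share one core and differ in a single place, (methyl in place of hydrogen on a saturated chain carbon bound to an amide-type nitrogen and a saturated chain carbon). The step between them, a 1.1-fold lower number from compound 1 to compound 2 (0.06 log units; within the scatter), is small. Compound 3 carries a different core: 4-chlorophenyl in place of 2-fluorophenyl on a saturated chain carbon bound to an aromatic nitrogen. The step of an at least 5.4-fold higher number from compound 1 to compound 3 (0.73 log units; beyond the scatter) shows a clear loss of potency, and the value of compound 3 is a limit, (the limit of > 128000 nM in this assay, at which 1 of the 3 values shown sits).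

Compound 4 `CC(C)NC(=O)N1CCN(C(=S)SCc2cn(Cc3ccc(Cl)cc3)nn2)CC1` has not yet been measured. It differs from compound 3 by methyl in place of hydrogen on a saturated chain carbon bound to an amide-type nitrogen and a saturated chain carbon, the same change that separates compound 1 from compound 2, at the same place. Because that change gave only a 1.1-fold lower number from compound 1 to compound 2 (0.06 log units; within the scatter), compound 4 is expected to stay close to compound 3 and most likely to return another limit rather than a number. The estimated step is a step that the limit leaves unreadable from compound 3 to compound 4. Compound 4 is therefore estimated at 150000 nM, with a range from 60000 nM to 400000 nM.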

Compound 4, half-maximal inhibitory concentration: 25600 nM
Estimate against measurement, compound 4: 5.9-fold (0.77 log units) above; measured number below the stated range.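

In this assay, ethyl to isopropyl on the core of compound 3 gave an at least 5.0-fold lower number from compound 3 to compound 4 (0.69 log units; beyond the scatter), so this change does not carry over from the core of compound 1 with the same effect: the same change on two cores in this assay, a 1.1-fold lower number (0.06 log units; within the scatter) from compound 1 to compound 2 and an at least 5.0-fold lower number (0.69 log units; beyond the scatter) from compound 3 to compound 4, at least 4.3-fold (0.64 log units) apart, beyond the scatter of two such steps
Seen from the other side, 4-chlorophenyl in place of 2-fluorophenyl gave a 1.2-fold higher number from compound 2 to compound 4 (0.09 log units; within the scatter) among the isopropyl compounds, so that change also depends on its partner group: the same change on two cores in this assay, an at least 5.4-fold higher number (0.73 log units; beyond the scatter) from compound 1 to compound 3 and a 1.2-fold higher number (0.09 log units; within the scatter) from compound 2 to compound 4, at least 4.3-fold (0.64 log units) apart, beyond the scatter of two such steps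
As far as these compounds go, the value of compound 3, > 128000 nM, is a limit and not a number, so the true size of these differences stays unknown, and two pairs give no rule for any other core.

From the compounds shown here alone, it remains open how a longer chain or a tert-butyl group in place of isopropyl would read in this assay on either core. Going by these compounds, it is also open whether a plain phenyl group in place of 4-chlorophenyl or 2-fluorophenyl would show the same dependence between the two places.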